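Cytotoxicity across the group on one aromatic carbon

This account rests on a few compounds, and the source may have more. Where it says the series, first, only, none or still open, it means among the compounds named here.

Three measured compounds share a core and differ only in the group on one aromatic carbon. Compound 1 `CCCCCOc1nc(N)nc2c1ncn2/C=C1/CC1(CO)CO` gives 259000 nM in an ADME assay on HFF cells (Homo sapiens) for cytotoxicity, with a stated time of 8 days; on this read-out lower numbers stand for higher toxicity in this test and higher numbers for lower toxicity in this test. Compound 2 `CN(C)c1nc(N)nc2c1ncn2/C=C1/CC1(CO)CO` reaches only a limit in this assay, > 300000 nM. Compound 3 `CCCCCCOc1nc(N)nc2c1ncn2/C=C1/CC1(CO)CO` likewise reaches only a limit in this assay, > 200000 nM. Compound 3 therefore stands at the end of the readable range, and of the three values shown one further value, that of compound 2, is also a limit rather than a number.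

Compound 4 `Nc1nc(SCc2ccccc2)c2ncn(/C=C3/CC3(CO)CO)c2n1` follows from compound 3 by benzylsulfanyl in place of hexyloxy on an aromatic carbon. Among the measured compounds shown here, the steps that bear on this change are those at the same aromatic carbon and along the chain: an at least 1.1-fold higher number from compound 1 to compound 2 (0.06 log units; that floor lies within the scatter); a step that the two limits leave unreadable from compound 2 to compound 3; a step that the limit leaves unreadable from compound 1 to compound 3. The two unreadable steps are unreadable because of the limit of > 200000 nM in this assay, at which 1 of the 3 values shown sits, and (the limit of > 300000 nM in this assay, at which 1 of the 3 values shown sits). For the measured compounds named here, the one readable step sits within the scatter. No step beyond the scatter is therefore expected in this assay; the step expected for compound 4 is a number no higher from compound 3 to compound 4 (the limit leaves the size open). Compound 4 is estimated at 200000 nM in this assay, with a range from 70000 nM to 400000 nM, and a limit rather than a number is a likely outcome.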

Compound 4, half-maximal cytotoxic concentration: > 300000 nM
Compound 4: only a limit was reported (the forecaster's own chance of this, stated with the estimate: 50%); at least 1.5-fold (0.17 log units) between middle value and limit.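

With benzylsulfanyl, the only group shown at this aromatic carbon that carries a six-membered aromatic ring of carbon only, compound 4 reaches only a limit in this assay, > 300000 nM. Among the compounds shown here, the one readable comparison is an at least 1.1-fold higher number from compound 1 to compound 4 (0.06 log units; that floor lies within the scatter), so swapping pentyloxy for this larger ring-bearing group gives no readable change in this read-out. The steps to compound 4 from compound 2 and compound 3 cannot be read, and the series now rests largely on limits rather than numbers: the limit of > 300000 nM in this assay, at which 2 of the 4 values shown sit.

The compounds shown leave open whether any group at this aromatic carbon gives a number clearly lower than those seen so far in this assay, and how far the true values of compound 2, compound 3 and compound 4 lie from their limits. Benzyloxy, which would separate the sulfur link from the ring, and a carboxylic acid or a primary amine at the same carbon, would test this read-out with groups not among those shown.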